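The source may hold more compounds than are shown below. What is called first, only, known or untested is meant among the compounds shown, and "the series" means these compounds.

Working notes on the series. Compound 1 has the structure `CCCNC(=C\C(=O)/C=C/c1ccc(O)c(OC)c1)/C=C/c1ccc(O)c(OC)c1` and compound 2 the structure `O=C(/C=C(/C=C/c1ccc(O)cc1)NC1CCCCC1)/C=C/c1ccc(O)cc1`. In a functional assay on Caco-2 cells (Homo sapiens) for inhibition, read by MTT assay, with a stated time of 72 h (a higher number here means a weaker inhibitor, a lower number a stronger inhibitor), compound 1 gives > 25000 nM, which is a limit of the assay and not a number. In this assay compound 2 gives 7800 nM. Within the data shown here, compound 1 thus stands only at the limit of > 25000 nM in this assay, at which 1 of the 2 values shown sits, and no measured step connects it with compound 2. Compound 3, with the structure `COc1cc(/C=C/C(=O)/C=C(/C=C/c2ccc(O)c(OC)c2)NCC(C)C)ccc1O`, has not yet been measured in this assay. It differs from compound 1 by methyl in place of hydrogen on a saturated chain carbon bound to two saturated chain carbons. Among the measured compounds shown here, no measured pair in the data shows a change of this kind, so the step in this assay between these two compounds is expected to be none beyond the scatter, and compound 3 is expected most probably to come back as a limit as well. For compound 3 the expected value in this assay is 30000 nM, with a range from 10000 nM to 100000 nM. The expected step is a step that the limit leaves unreadable from compound 1 to compound 3.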

Compound 3, half-maximal inhibitory concentration: > 25000 nM
Compound 3 gave a limit, no number; the forecaster's own chance of this, stated with the estimate: 70%; the middle value does not contradict the limit.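

No step can be read between compound 1 and compound 3, as each gives only a limit of the assay and not a number: the limit of > 25000 nM in this assay, at which 2 of the 3 values shown sit.

On these data alone, whether methyl in place of hydrogen on a saturated chain carbon bound to two saturated chain carbons shifts the value in this assay stays open.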